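This account rests on a few compounds, and the source may have more. Where it says the series, first, only, none or still open, it means among the compounds named here.

Measured so far:
compound 1, `Cc1ccc(C(=O)Nc2nc(Cl)c3cn(CC(C)(C)C)nc3n2)cc1`, with 5000 nM
compound 2, `Cc1ccc(C(=O)Nc2nc(Cl)c3cn(C(C)C)nc3n2)cc1`, with > 100000 nM
compound 3, `CC(C)n1cc2c(Cl)nc(NC(=O)c3ccc(F)cc3)nc2n1`, with > 60000 nM

All three values come from an assay on CHO cells for displacement of a labelled ligand from adenosine receptor A3 (Homo sapiens), read by scintillation counting, with a stated time of 3 h; on this read-out higher numbers stand for weaker inhibition and lower numbers for stronger inhibition. For compound 2 the value is only a limit of the assay, not a number. For compound 3 the value is likewise a limit and not a number. Compound 2 and compound 1 differ in one place: neopentyl in place of isopropyl on an aromatic nitrogen. That single change produced an at least 20-fold lower number from compound 2 to compound 1 (1.30 log units; beyond the scatter). Compound 2 and compound 3 differ in their cores: fluoro in place of methyl on an aromatic carbon. The step between them, a step that the two limits leave unreadable from compound 2 to compound 3, cannot be sized because the limit of > 100000 nM in this assay, at which 1 of the 3 values shown sits, and the limit of > 60000 nM in this assay, at which 1 of the 3 values shown sits, are both limits and not numbers.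

Compound 4, `CC(C)(C)Cn1cc2c(Cl)nc(NC(=O)c3ccc(F)cc3)nc2n1`, has not yet been measured in this assay. It differs from compound 3 in one place: neopentyl in place of isopropyl on an aromatic nitrogen. Going by the values given here, this is the same change as the one from compound 2 to compound 1, made on the core of compound 3 instead. A drop of comparable size is expected, an at least 10-fold lower number from compound 3 to compound 4 (1.00 log units; beyond the scatter), resting on an at least 20-fold lower number from compound 2 to compound 1 (1.30 log units; beyond the scatter). Because the limit of > 60000 nM in this assay, at which 1 of the 3 values shown sits, gives only a limit for compound 3, the starting point is not exactly known, so the expected landing point is wide. Compound 4 is expected at about 6000 nM, most likely between 1500 nM and 40000 nM.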

Compound 4, inhibition constant: 5900 nM
Estimate against measurement, compound 4: 1.0-fold (0.01 log units) above; low and high end bracket the measured number.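

In this assay, carrying neopentyl in place of isopropyl on an aromatic nitrogen over to the core of compound 3 gave an at least 10-fold lower number from compound 3 to compound 4 (1.00 log units; beyond the scatter), so the drop seen on the core of compound 1 appears on a second core: the same change on two cores in this assay, an at least 20-fold lower number (1.30 log units; beyond the scatter) from compound 2 to compound 1 and an at least 10-fold lower number (1.00 log units; beyond the scatter) from compound 3 to compound 4; the limit leaves it open whether they differ

With neopentyl in place on both cores, swapping fluoro in place of methyl on an aromatic carbon gives a 1.2-fold higher number from compound 1 to compound 4 (0.07 log units; within the scatter), which means the two neopentyl compounds cannot be told apart in this assay. On these data alone, the values of compound 2 and compound 3 are limits of the assay and not numbers, so the true size of each neopentyl step stays unknown, the step between those two compounds cannot be read, and two cores are too few to make a rule for the whole series.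

The compounds shown leave open whether a longer chain, such as n-hexyl, on that aromatic nitrogen would bring the number lower still or raise it again. They also leave open whether the neopentyl step would carry over to a core with a methoxy group or a nitrile on the aromatic carbon that holds fluoro or methyl here.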